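This account rests on a few compounds, and the source may have more. Where it says the series, first, only, none or still open, it means among the compounds named here.

Measured so far:
compound 1, `Cc1cc(C)c2sc(NC(=O)c3ccc(C(F)(F)F)cc3)nc2c1`, 1.36 ug/mL
compound 2, `COc1ccc2sc(NC(=O)c3ccc(C#N)cc3)nc2c1`, > 10 ug/mL

Both values come from a functional assay on SK-HEP1 cells (Homo sapiens) for antiproliferative activity, read by sulforhodamine B assay; on this read-out lower numbers stand for stronger inhibition of growth and higher numbers for weaker inhibition of growth. Compound 1 gives a number, 1.36 ug/mL. For compound 2 the result is only a limit, > 10 ug/mL; this is the case described by the limit of > 10 ug/mL in this assay, at which 1 of the 2 values shown sits. Compound 2 therefore stands at the weak end of what this assay reports, and no number places it further.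

Compound 3, `COc1ccc2sc(NC(=O)c3ccc([N+](=O)[O-])cc3)nc2c1`, is not yet measured. It differs from compound 2 in one place: nitro in place of cyano on an aromatic carbon. The rest of the structure is unchanged.

Among the compounds with values here, no measured step between compounds is available, so the size of this change in this assay is not known from the data. Neither a gain nor a loss beyond the usual scatter is expected for the step of a number no higher from compound 2 to compound 3 (the limit leaves the size open). For compound 3 the estimated value in this assay is 10 ug/mL, with a range from 3 ug/mL to 30 ug/mL, and a fair chance that again only a limit is reported.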

Compound 3, concentration for 50% growth inhibition: > 10 ug/mL
Compound 3: no number, only a limit (the forecaster's own chance of this, stated with the estimate: 60%); the middle value sits exactly at the limit.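

Compound 2 and compound 3 both return only a limit, so no step can be read between them, because both results stand at the assay's limit: the limit of > 10 ug/mL in this assay, at which 2 of the 3 values shown sit. The compounds shown leave open whether nitro in place of cyano changes the result in this assay at all.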